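Sulfonamide Amine Variation in a Prostaglandin D2 Receptor Series

The compounds below may be only part of what the source reports. "The series", "measured", "known", "first", "only" and "open" are said of these compounds alone.

Measured compounds:
compound 1 `Cc1ncc(S(=O)(=O)N(C)C)cc1C#Cc1cc(Cl)ccc1OCC(=O)O`: 41 nM
compound 2 `Cc1ccc(S(=O)(=O)NC(C)C)cc1C#Cc1cc(Cl)ccc1OCC(=O)O`: 3.4 nM
compound 3 `COCc1ccc(C#Cc2cc(Cl)ccc2OCC(=O)O)c(F)c1`: 22 nM

All three were characterised in an assay on CHO cells for displacement of a labelled ligand from prostaglandin D2 receptor 2 (Homo sapiens), read by scintillation counting; on this read-out lower numbers stand for stronger inhibition and higher numbers for weaker inhibition. Compound 2 gives the lowest number of the three; the gaps to compound 3 and to compound 1 both lie beyond the usual scatter, so compound 2 is the most potent of the measured set. Compound 4 `Cc1ccc(S(=O)(=O)N2CCOCC2)cc1C#Cc1cc(Cl)ccc1OCC(=O)O` has not yet been measured. It differs from compound 2 in one place: morpholin-4-yl in place of isopropylamino on a sulfonyl sulfur. For the measured compounds named here, no pair of measured compounds differing in a single place is available, so the size of this step cannot be read from the data. A moderate weakening is expected, and a 2.9-fold higher number from compound 2 to compound 4 (0.47 log units; beyond the scatter) is the estimated step. Compound 4 is expected to give 10 nM, with a range from 3 nM to 35 nM.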

Compound 4, inhibition constant: 3.6 nM
For compound 4 the middle estimate is 2.8-fold (0.44 log units) above the measured one; measured number inside the range.
By their numbers in this assay, from the lowest: compounds 2 and 4 (each within the scatter of the next); then compounds 3 and 1 (each within the scatter of the next).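

In this assay replacing isopropylamino with morpholin-4-yl on a sulfonyl sulfur gives a 1.1-fold higher number from compound 2 to compound 4 (0.02 log units; within the scatter) and so shows that this position accepts a six-membered non-aromatic ring in place of an open branched group. The hydrogen-bond donor of isopropylamino is also absent from compound 4 without a change beyond the scatter. Nothing available explains this result. Going by these compounds, whether piperidin-1-yl, which lacks the ring oxygen, or piperazin-1-yl, which has a ring nitrogen in its place, would fit this pattern remains open.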